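The source may hold more compounds than are shown below. What is called first, only, known or untested is meant among the compounds shown, and "the series" means these compounds.

Of the compounds shown here, three sharing one core have so far been read in a physicochemical assay for solubility, read by spectrophotometry, measured as kinetic solubility, at pH 8, tested at 500 uM (on this read-out lower numbers stand for lower solubility and higher numbers for higher solubility), and give these numbers. Compound 1 `CN(C)C(=O)c1ccncc1Nc1cc(-c2ccc3ccn(C)c3c2)c2nccnc2c1` stands at 175 ug/mL and compound 2 `Cn1ccc2ccc(-c3cc(Nc4cnccc4C(=O)NC4CCNC(=O)C4)cc4nccnc34)cc21` at 242 ug/mL while compound 3 `CN1CC(NC(=O)c2ccncc2Nc2cc(-c3ccc4ccn(C)c4c3)c3nccnc3c2)CCC1=O` stands at 253 ug/mL in the same measurement. All three lie within the scatter of one another, so compound 3 cannot be separated from either neighbour.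

Compound 4 `CC(=O)N1CCOC(CNC(=O)c2ccncc2Nc2cc(-c3ccc4ccn(C)c4c3)c3nccnc3c2)C1` alters compound 3 in one place only, on the amide-type nitrogen whose other neighbour is the carbonyl carbon. There, (4-acetylmorpholin-2-yl)methyl stands in place of 1-methyl-6-oxopiperidin-3-yl, and the counted difference is (4-acetylmorpholin-2-yl)methyl in place of 1-methyl-6-oxopiperidin-3-yl on an amide-type nitrogen (as computed from the two structures).

For the measured compounds named here, three measured steps bear on this change. Exchanging dimethylamino on a carbonyl carbon gave a 1.4-fold higher number from compound 1 to compound 2 (0.14 log units; within the scatter) with (2-oxopiperidin-4-yl)amino and a 1.4-fold higher number from compound 1 to compound 3 (0.16 log units; within the scatter) with (1-methyl-6-oxopiperidin-3-yl)amino. The nearest analogy, one group exchanged for another on that same nitrogen, gave a 1.0-fold higher number from compound 2 to compound 3 (0.02 log units; within the scatter) and stayed flat. Going by the values given here, no measured compound carries the (4-acetylmorpholin-2-yl)methyl group, so the expectation rests on analogy alone. The expected step is a 1.1-fold lower number from compound 3 to compound 4 (0.02 log units; within the scatter) and no move beyond the scatter in this assay is foreseen. Compound 4 is therefore estimated at 240 ug/mL (expected range 150 ug/mL to 290 ug/mL).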

Compound 4, solubility: 268 ug/mL
The estimate for compound 4 lay 1.1-fold (0.05 log units) below the measured number, and the stated range covers the measured number.
By their numbers in this assay, from the lowest: compounds 1, 2, 3 and 4 (each within the scatter of the next).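

Placing (4-acetylmorpholin-2-yl)methyl on the amide-type nitrogen gave a 1.1-fold higher number from compound 3 to compound 4 (0.03 log units; within the scatter) and a 1.1-fold higher number from compound 2 to compound 4 (0.04 log units; within the scatter) in this assay, so a group of 10 heavy atoms, with a six-membered non-aromatic ring holding 2 hetero atoms, could not be separated there from either 1-methyl-6-oxopiperidin-3-yl or 2-oxopiperidin-4-yl. Measured against dimethylamino on the carbonyl carbon, the same exchange gave a 1.5-fold higher number from compound 1 to compound 4 (0.19 log units; within the scatter), and even this, the largest step among the four compounds, stayed within the scatter, so no substituent shown at this position has yet been separated from another in this read-out. Nothing at hand offers a reason for this flat result.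

All the groups shown at this position carry no net charge, so it remains open whether an amine such as piperidin-4-yl, or a carboxylic acid on a short chain, would move the number beyond the scatter. From the compounds shown here alone, it also remains open whether any exchange elsewhere on the shared core, such as at the 1-methylindole-like group's place, would do so.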